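The source may hold more compounds than are shown below. What is called first, only, known or untested is meant among the compounds shown, and "the series" means these compounds.

Compound 1 `C=CC(=O)Nc1cc(Oc2ccc(NC(=O)Nc3ccc(C)c(C(F)(F)F)c3)cc2)ncn1` gives 1940 nM in a functional assay on BaF3 cells (Mus musculus) for inhibition, read by CCK-8 assay, with a stated time of 72 h; a lower number here means a stronger inhibitor of growth, a higher number a weaker inhibitor of growth. Compound 2 `Cc1ccc(NC(=O)Nc2ccc(Oc3cc(NCCN)ncn3)cc2)cc1C(F)(F)F` reaches only a limit of this assay, standing at > 10000 nM. Compound 3 `Cc1ccc(NC(=O)Nc2ccc(Oc3cc(N4CCNC[C@H]4C)ncn3)cc2)cc1C(F)(F)F` gives 9670 nM in this assay, the highest of the two numbers shown, set apart from compound 1 by a 5.0-fold higher number from compound 1 to compound 3 (0.70 log units; beyond the scatter), while the comparison with compound 2 is only an at least 1.0-fold lower number from compound 2 to compound 3 (0.01 log units; that floor lies within the scatter) and rests on (the limit of > 10000 nM in this assay, at which 1 of the 3 values shown sits). Compound 4 `Cc1ccc(NC(=O)Nc2ccc(Oc3cc(N4CCNC[C@@H]4C)ncn3)cc2)cc1C(F)(F)F` differs from compound 3 by the two compounds have the same atoms and bonds and differ only in configuration as drawn: 1 of 1 stereo elements differ; a stereocentre at a saturated ring carbon is drawn R in compound 3 and S in compound 4. Going by the values given here, none of the measured steps concerns configuration alone; both steps reaching compound 3 changed a whole group. The expected step from compound 3 to compound 4 is therefore a 1.1-fold lower number from compound 3 to compound 4 (0.06 log units; within the scatter), nothing beyond the scatter. Compound 4 is estimated at 8500 nM, ranging from 3000 nM to 25000 nM.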

Compound 4, concentration for 50% growth inhibition: 8120 nM
Compound 4: middle estimate off by 1.0-fold (0.02 log units), on the high side, within the range that was stated.
By their numbers in this assay, from the lowest: compound 1; then compounds 4 and 3 (each within the scatter of the next). At a limit, above all of these: compound 2.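

In this assay the change of configuration alone, at the stereocentre at the saturated ring carbon, drawn R or S, gives a 1.2-fold lower number from compound 3 to compound 4 (0.08 log units; within the scatter): the fact that compounds 3 and 4 differ only in the configuration as drawn. With either configuration, 2-methylpiperazin-1-yl does not match the (vinylcarbonyl)amino group of compound 1, with a 4.2-fold higher number from compound 1 to compound 4 (0.62 log units; beyond the scatter) standing beyond the scatter. Only a floor can be given for the remaining step, an at least 1.2-fold lower number from compound 2 to compound 4 (0.09 log units; that floor lies within the scatter), which rests on a limit: the limit of > 10000 nM in this assay, at which 1 of the 4 values shown sits.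

As far as these compounds go, whether an unsubstituted piperazin-1-yl group would stand any closer to compound 1 remains open.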